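One methyl added to compound 2

This account rests on a few compounds, and the source may have more. Where it says the series, first, only, none or still open, it means among the compounds named here.

compound 1 `CC(C)(C)c1ccc(S(=O)(=O)Nc2ccccc2)cc1` gives 16000 nM
compound 2 `CC(C)(C)c1ccc(S(=O)(=O)Nc2cccc(O)c2)cc1` gives 12000 nM

For the measured compounds named here, in a functional assay on A549 cells (Homo sapiens) for inhibition (a lower number here means a stronger inhibitor of growth, a higher number a weaker inhibitor of growth), compound 2 stands level with compound 1, and the gap between them is the only measured step (a 1.3-fold lower number from compound 1 to compound 2 (0.12 log units; within the scatter)). Compound 3 `Cc1ccc(NS(=O)(=O)c2ccc(C(C)(C)C)cc2)cc1O` has methyl in place of hydrogen on an aromatic carbon, ortho to a hydroxy group (methyl in place of hydrogen on an aromatic carbon). The measured step brought in hydroxy, not methyl, and it lies within the scatter, so it offers little guidance here. No shift beyond the scatter is expected in either direction, and the expected step is correspondingly slight (a 1.1-fold lower number from compound 2 to compound 3 (0.04 log units; within the scatter)). Compound 3 is estimated at 11000 nM (expected range 5500 nM to 22000 nM).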

Compound 3, concentration for 50% growth inhibition: 6000 nM
Compound 3: middle estimate off by 1.8-fold (0.26 log units), on the high side, within the range that was stated.
By their numbers in this assay, from the lowest: compounds 3, 2 and 1 (each within the scatter of the next, the first and the last beyond it).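

In this assay, methyl in place of hydrogen on this aromatic carbon, ortho to a hydroxy group, gives a 2.0-fold lower number from compound 2 to compound 3 (0.30 log units; within the scatter). The added methyl therefore leaves the growth inhibition level with that of compound 2, so this carbon can carry a small group with no shift beyond the scatter. No measurement here bears on what lies behind this step.

On these data alone, whether an ethyl group, a methoxy group, an amine or a carboxylic acid at this carbon would behave the same way stays open. So does whether methyl would give a similar result without the hydroxy group.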